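Swapping a chlorophenyl for pyridyl on the benzyl arm

This account rests on a few compounds, and the source may have more. Where it says the series, first, only, none or still open, it means among the compounds named here.

Three compounds built on one shared core have been examined in a functional assay on L02 cells (Homo sapiens) for inhibition, read by Griess assay, with stated times of 1 h and 24 h; on this read-out lower numbers stand for stronger inhibition and higher numbers for weaker inhibition. Compound 1 `COc1cc(/C=C/c2nc(N3CCN(C)CC3)c3sccc3n2)cc(OC)c1OC` carries a 4-methylpiperazin-1-yl group, and in this assay compound 1 reaches only the limit > 1000000 nM. Compound 2 `COc1ccc(Nc2nc(/C=C/c3cc(OC)c(OC)c(OC)c3)nc3ccsc23)cc1` carries a (4-methoxyphenyl)amino group instead, and in this assay compound 2 gives 279000 nM, which is an at least 3.5-fold lower number from compound 1 to compound 2 (0.55 log units; beyond the scatter). Compound 3 `COc1cc(/C=C/c2nc(NCc3ccc(Cl)cc3)c3sccc3n2)cc(OC)c1OC` carries a (4-chlorobenzyl)amino group, and in this assay compound 3 again reaches only the limit > 1000000 nM. So compound 3 stands at the limit, with an at least 3.5-fold higher number from compound 2 to compound 3 (0.55 log units; beyond the scatter) and a step that the two limits leave unreadable from compound 1 to compound 3; the limit of > 1000000 nM in this assay, at which 2 of the 3 values shown sit, shows how much of the set sits there.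

Compound 4 `COc1cc(/C=C/c2nc(NCc3ccncc3)c3sccc3n2)cc(OC)c1OC` differs from compound 3 by pyridin-4-yl in place of 4-chlorophenyl on a saturated chain carbon bound to a nitrogen on an aromatic ring. Within the data shown here, no measured step tests this exchange: each measured step swaps the whole group attached to the core, whereas here the benzyl arm is kept and only its ring is altered. Because compound 3 sits at > 1000000 nM, the step of a number no higher from compound 3 to compound 4 (the limit leaves the size open) is expected to be small. The value for compound 4 is therefore estimated at about 1000000 nM, between 300000 nM and 3000000 nM, most likely again reported only as a limit.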

Compound 4, half-maximal inhibitory concentration: 374000 nM
Beside the measured number, compound 4's estimate is 2.7-fold (0.43 log units) above it; the measured number falls inside the stated range.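

In this assay, the ring on the benzyl arm matters on its own: keeping the arm and placing pyridin-4-yl where 4-chlorophenyl stood gives an at least 2.6-fold lower number from compound 3 to compound 4 (0.42 log units; beyond the scatter). The earlier steps shown here each replaced the whole group on the core, so they could not show that a benzyl-type arm can come off the limit; the new value also gives an at least 2.6-fold lower number from compound 1 to compound 4 (0.42 log units; beyond the scatter), and a 1.3-fold higher number from compound 2 to compound 4 (0.13 log units; within the scatter), which leaves no order between those two. The steps that start from a limit give only a minimum size, and the set still leans heavily on that limit: the limit of > 1000000 nM in this assay, at which 2 of the 4 values shown sit.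

With a single ring exchange on this arm, the loss of the chlorine and the arrival of the ring nitrogen cannot be separated, and a plain phenyl ring on the same arm would divide the two. Also open, as far as these compounds go, are whether pyridin-3-yl would behave like pyridin-4-yl, and whether a longer chain between the amine and the ring would keep the value of compound 4.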